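Swapping a Chlorinated Benzyl for Phenethyl: Cytotoxicity Outlook

The source may hold more compounds than are shown below. What is called first, only, known or untested is meant among the compounds shown, and "the series" means these compounds.

Of the compounds shown here, two sharing one core have been tested in an ADME assay on HEL cells (Homo sapiens) for cytotoxicity, with a stated time of 3 days; on this read-out higher numbers stand for lower toxicity in this test and lower numbers for higher toxicity in this test. Compound 1 `CCC1(Cc2ccccc2)OS(=O)(=O)C=C1OCc1ccccc1Cl` gives only a limit in this assay, >= 20000 nM, so its minimum cytotoxic concentration is known as a bound rather than as a number. Compound 2 `CCCC1(Cc2ccccc2)OS(=O)(=O)C=C1OCc1ccccc1` likewise gives only a limit in this assay, >= 400000 nM. For the measured compounds named here, because both readings are bounds the limit of >= 20000 nM in this assay, at which 1 of the 2 values shown sits (the limit of >= 400000 nM in this assay, at which 1 of the 2 values shown sits), no step between measured compounds can be drawn, and compound 1 therefore stands at a bound with no ordering against compound 2.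

Compound 3 `CCC1(Cc2ccccc2)OS(=O)(=O)C=C1OCCc1ccccc1` has not yet been measured. It differs from compound 1 in one place: benzyl in place of 2-chlorophenyl on a saturated chain carbon bound to an oxygen on an unsaturated carbon. Going by the values given here, no measured step of this kind exists in the data, so the expectation must rest on the two bounds alone. The step expected in this assay is a step that the limit leaves unreadable from compound 1 to compound 3, which is nothing beyond the scatter. Compound 3 is expected to show 40000 nM in this assay, within a range from 10000 nM to 400000 nM, and most likely to return another limit rather than a number.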

Compound 3, minimum cytotoxic concentration: >= 20000 nM
Compound 3: only a limit was reported; the forecaster's own chance of this, stated with the estimate: 80%; the middle value lies beyond the limit too.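

Compound 1 and compound 3 each return only a limit in this assay, so no step can be read from compound 1 to compound 3: the limit of >= 20000 nM in this assay, at which 2 of the 3 values shown sit.

The compounds shown leave open whether replacing 2-chlorobenzyl with phenethyl changes the minimum cytotoxic concentration at all, and in which direction any such change would run.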